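This account rests on a few compounds, and the source may have more. Where it says the series, first, only, none or still open, it means among the compounds named here.

In a functional assay on HT-1080 cells (Homo sapiens) for antiproliferative activity, read by sulforhodamine B assay, with a stated time of 48 h (a lower number here means a stronger inhibitor, a higher number a weaker inhibitor), compound 2 `CCCCCNC(=O)Nc1ccc(S(=O)(=O)Oc2ccccc2I)cc1` gives 6900 nM. Within the data shown here, it is one of only two compounds measured here, and its sole neighbour is compound 1 `CCCCCC(=O)Nc1ccc(S(=O)(=O)Oc2ccccc2I)cc1`, which in this assay gives 9600 nM; the step of a 1.4-fold lower number from compound 1 to compound 2 (0.14 log units; within the scatter) lies within the scatter, so the two numbers cannot be told apart. Compound 3 `O=C(NCCCCl)Nc1ccc(S(=O)(=O)Oc2ccccc2I)cc1` is the next step from compound 2, and the change is chloro in place of ethyl on a saturated chain carbon, three bonds along the chain from an amide-type nitrogen. Among the measured compounds shown here, the only measured step, a 1.4-fold lower number from compound 1 to compound 2 (0.14 log units; within the scatter), alters the carbonyl side of the urea and leaves the pentyl chain untouched, so nothing measured bears directly on a change at the far end of that chain. The expectation is therefore a step of a 1.0-fold higher number from compound 2 to compound 3 (0.01 log units; within the scatter), that is, no change beyond the scatter. Compound 3 is estimated at 7000 nM, with a range from 3000 nM to 16000 nM.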

Compound 3, half-maximal inhibitory concentration: 2800 nM
The estimate for compound 3 lay 2.5-fold (0.40 log units) above the measured number, and the stated range ends above it.
By their numbers in this assay, from the lowest: compound 3; then compounds 2 and 1 (each within the scatter of the next).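

Among these compounds, the far end of the chain, which no earlier step touched, turns out to matter in this assay: chloro in place of ethyl, three bonds along the chain from an amide-type nitrogen, gives a 2.5-fold lower number from compound 2 to compound 3 (0.39 log units; beyond the scatter), the first step here beyond the scatter. Placing (3-chloropropyl)amino in place of pentyl on the carbonyl carbon gives a 3.4-fold lower number from compound 1 to compound 3 (0.54 log units; beyond the scatter), whereas the pentylamino change alone stayed within the scatter, so the chain end and not that change alone accounts for a clear difference in these compounds. Nothing measured here explains why the number falls.

From the compounds shown here alone, it remains open whether the chlorine or the shortened chain matters, since this change alters both; a plain propyl chain would separate the two. A 3-fluoropropyl or 3-bromopropyl chain would show whether other halogens at that place give a similar number.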